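Bromophenyl for fluorophenylamino on the sulfonyl sulfur

The source may hold more compounds than are shown below. What is called first, only, known or untested is meant among the compounds shown, and "the series" means these compounds.

In a functional assay on K562 cells (Homo sapiens) for inhibition, read by trypan blue exclusion, with a stated time of 72 h (a lower number here means a stronger inhibitor, a higher number a weaker inhibitor), compound 1 (`Cn1c(=O)c(C(=O)Nc2ccc(F)cc2)cc2cnc(Nc3ccc4[nH]ccc4c3)nc21`) gives 5000 nM. Compound 2 (`Cn1c(=O)c(S(=O)(=O)Nc2ccc(F)cc2)cc2cnc(Nc3ccc4[nH]ccc4c3)nc21`) gives 5000 nM, level with compound 1 at the digits available.

Compound 3 (`Cn1c(=O)c(S(=O)(=O)c2ccc(Br)cc2)cc2cnc(Nc3ccc4[nH]ccc4c3)nc21`) keeps the shared core and the sulfonyl group of compound 2. The change is 4-bromophenyl in place of (4-fluorophenyl)amino on a sulfonyl sulfur.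

For the measured compounds named here, only one measured step bears on this, and only indirectly: no change at the digits printed from compound 1 to compound 2 (within the scatter), with (4-fluorophenyl)sulfamoyl in place of (4-fluorophenyl)carbamoyl on an aromatic carbon. Going by the values given here, that step altered the same substituent without a shift in the read-out, but no measured pair replaces the (4-fluorophenyl)amino group itself. The series therefore offers no direction for this change, and the evidence is thin.

In this assay, no step beyond the scatter is expected, though a wide range is warranted. The expected step is a 1.3-fold lower number from compound 2 to compound 3 (0.10 log units; within the scatter). For compound 3 the estimated value is 4000 nM, with an expected range of 1300 nM to 12000 nM.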

Compound 3, half-maximal inhibitory concentration: 5000 nM
Compound 3: middle estimate off by 1.3-fold (0.10 log units), on the low side, and the stated range covers the measured number.
By their numbers in this assay, from the lowest: compounds 1, 2 and 3 (each within the scatter of the next).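

In this assay, the step with 4-bromophenyl in place of (4-fluorophenyl)amino on the sulfonyl sulfur gives no change at the digits printed from compound 2 to compound 3 (within the scatter), so removing the hydrogen-bond donor counted in the leaving group leaves the read-out unmoved in this pair. The wider comparison, with (4-bromophenyl)sulfonyl in place of (4-fluorophenyl)carbamoyl on the aromatic carbon, gives no change at the digits printed from compound 1 to compound 3 (within the scatter), so the carbamoyl, sulfamoyl and sulfonyl forms now all stand at one printed number, whereas the earlier pair covered only the first two. Nothing measured accounts for this flat result.

The step from compound 2 to compound 3 changes the nitrogen and the halogen together, so a plain 4-fluorophenyl on the sulfonyl sulfur would be needed to read the two apart. All three compounds also carry a halogenated six-membered aromatic ring at this place, which leaves open whether a methyl on the sulfonyl sulfur, or a carboxylic acid on the aromatic carbon, would move the number in this assay.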